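Compound 3: 2,4-dichlorophenyl in place of phenyl

This account rests on a few compounds, and the source may have more. Where it says the series, first, only, none or still open, it means among the compounds named here.

Measured so far in a functional assay on SF-539 cells (Homo sapiens) for inhibition, read by sulforhodamine B assay, with a stated time of 48 h; a lower number here means a stronger inhibitor of growth, a higher number a weaker inhibitor of growth:
- compound 1 `O=C(Cc1csc2nc(-c3ccc(Br)cc3)cn12)N/N=C/c1ccccc1` gives 39800 nM
- compound 2 `COc1cccc(OC)c1/C=N/NC(=O)Cc1csc2nc(-c3ccc(Br)cc3)cn12` gives 24500 nM

Compound 1 has only compound 2 to compare with, and the two lie within the scatter of each other. The change to compound 3 `O=C(Cc1csc2nc(-c3ccc(Br)cc3)cn12)N/N=C/c1ccc(Cl)cc1Cl` is 2,4-dichlorophenyl in place of phenyl on a carbon with a double bond to nitrogen and amounts to 2,4-dichlorophenyl in place of phenyl on a carbon with a double bond to nitrogen. Among the measured compounds shown here, the only measured step at that place, with 2,6-dimethoxyphenyl in place of phenyl, is a 1.6-fold lower number from compound 1 to compound 2 (0.21 log units; within the scatter) and gives no firm lead. No step beyond the scatter is therefore expected in this assay for this change. The expected step is a 1.3-fold lower number from compound 1 to compound 3 (0.12 log units; within the scatter) by this estimate. For compound 3 the estimate is 30000 nM with an expected range from 12000 nM to 70000 nM as a working figure.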

Compound 3, concentration for total growth inhibition: 63100 nM
For compound 3 the middle estimate is 2.1-fold (0.32 log units) below the measured one; low and high end bracket the measured number.
By their numbers in this assay, from the lowest: compounds 2, 1 and 3 (each within the scatter of the next, the first and the last beyond it).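

In this assay, 2,4-dichlorophenyl in place of phenyl on the carbon with a double bond to nitrogen gives a 1.6-fold higher number from compound 1 to compound 3 (0.20 log units; within the scatter), so these two groups are not separated at this position. Set against 2,6-dimethoxyphenyl, the same group gives a 2.6-fold higher number from compound 2 to compound 3 (0.41 log units; beyond the scatter), the first step in the series beyond the scatter, which shows that exchanging one substituted phenyl for another here can register, if only modestly. Nothing available explains this step.

Still open, as far as these compounds go, is how a phenyl carrying an amine or a carboxylic acid would read in this assay. Also open, from the compounds shown here alone, is whether a single methoxy or a single chlorine on the phenyl would give the same separation.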